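Solubility notes on three measured amides and one pending analogue

The source may report more compounds than this note shows. Statements on the series, on what has been measured and on what is new or still open speak of the compounds shown alone.

Measured so far in a physicochemical assay for solubility, at pH 7; a higher number here means a more soluble compound, a lower number a less soluble compound:
- compound 1 `CC1(C)c2[nH]nc(NC(=O)c3ccc(F)cc3)c2CN1C(=O)C1CCN(C2CC2)CC1`: > 225000 nM
- compound 2 `CCCNC(=O)Nc1n[nH]c2c1CN(C(=O)C1CCN(C)CC1)C2(C)C`: > 225000 nM
- compound 3 `CN(C)CC(=O)Nc1n[nH]c2c1CN(C(=O)C(C)(C)C)C2(C)C`: > 225000 nM

Each of these values is a limit of the assay, not a number. Compound 2 sits at > 225000 nM, a limit. The same holds for compound 1 and compound 3, as the limit of > 225000 nM in this assay, at which 3 of the 3 values shown sit, shows, so no ordering among the three is possible and compound 2 cannot be placed relative to the others beyond sharing that limit.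

Compound 4 `CN1CCC(C(=O)N2Cc3c(NC(=O)c4ccc(C(F)(F)F)cc4)n[nH]c3C2(C)C)CC1` is the pending analogue. Its change from compound 2 is 4-(trifluoromethyl)phenyl in place of propylamino on a carbonyl carbon. In words, 4-(trifluoromethyl)phenyl in place of propylamino on a carbonyl carbon whose other neighbours are an amide-type nitrogen.

For the measured compounds named here, no step between measured compounds is available, so nothing here sets a size for this change. With compound 2 known only as a limit, the expected step of an at least 1.8-fold lower number from compound 2 to compound 4 (0.27 log units; that floor lies within the scatter) in this assay is downward, though compound 1, which also carries an aromatic amide, shows the limit of > 225000 nM in this assay, at which 3 of the 3 values shown sit, and gives some reason to expect compound 4 to remain soluble. The estimate for compound 4 is 120000 nM, within 30000 nM to 300000 nM, with a fair chance the assay again reports only a limit.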

Compound 4, solubility: 191000 nM
Compound 4: middle estimate off by 1.6-fold (0.20 log units), on the low side; measured number inside the range.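

In this assay, for the compounds shown here, compound 4 gives 191000 nM, the first reading in this set that is a number and not a limit, so this carbonyl carbon now carries a value that can be placed. Compound 2 stands at > 225000 nM, which is a limit of the assay. Putting 4-(trifluoromethyl)phenyl in place of propylamino gives an at least 1.1-fold lower number from compound 2 to compound 4 (0.07 log units; that floor lies within the scatter), so the change is not shown to lower the number beyond the scatter, though the true step may be larger.

From the compounds shown here alone, the size of that step stays open, and compound 2 cannot be fixed more closely: the limit of > 225000 nM in this assay, at which 3 of the 4 values shown sit. Also open is how a carboxylic acid or a longer chain on this carbonyl carbon would read in this assay.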